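Replacing the oxetanyloxy group of the amide with ethyl

The source may hold more compounds than are shown below. What is called first, only, known or untested is meant among the compounds shown, and "the series" means these compounds.

Compound 1 `O=C(Nc1cccc(Cl)c1)N1CCc2[nH]nc(-c3ccccc3)c2C1` gives 192 mL/min/kg in an ADME assay on microsomes from liver (Homo sapiens) for metabolic stability; on this read-out lower numbers stand for slow clearance and higher numbers for fast clearance.
Compound 2 `CC(C)ON(C)C(=O)c1n[nH]c2c1CN(C(=O)Nc1cccc(Cl)c1)CC2` gives 65 mL/min/kg in this assay.
Compound 3 `CN(OC1COC1)C(=O)c1n[nH]c2c1CN(C(=O)Nc1cccc(Cl)c1)CC2` gives 8 mL/min/kg in this assay.

Compound 3 stands lowest of the three measured values; the nearest value is reached by an 8.1-fold lower number from compound 2 to compound 3 (0.91 log units; beyond the scatter), the furthest by a 24-fold lower number from compound 1 to compound 3 (1.38 log units; beyond the scatter). Compound 4 `CCN(C)C(=O)c1n[nH]c2c1CN(C(=O)Nc1cccc(Cl)c1)CC2` differs from compound 3 in one place: ethyl in place of (oxetan-3-yl)oxy on an amide-type nitrogen.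

Within the data shown here, two measured steps bear on this change. The step of an 8.1-fold lower number from compound 2 to compound 3 (0.91 log units; beyond the scatter) shows how much the oxetan-3-yl contributed to the low number of compound 3, and a 24-fold lower number from compound 1 to compound 3 (1.38 log units; beyond the scatter) shows the whole effect of the methyl((oxetan-3-yl)oxy)carbamoyl. Compound 4 retains neither the oxetan-3-yl nor the oxygen of compound 3, so in this assay the number is expected to rise, by a modest step, though probably not back to the level of compound 1. The estimate for compound 4 is 50 mL/min/kg, with a range from 20 mL/min/kg to 130 mL/min/kg. This corresponds to an expected 6.3-fold higher number from compound 3 to compound 4 (0.80 log units; beyond the scatter).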

Compound 4, clearance: 87 mL/min/kg
For compound 4 the middle estimate is 1.7-fold (0.24 log units) below the measured one; the measured number falls inside the stated range.
By their numbers in this assay, from the lowest: compound 3; then compounds 2 and 4 (each within the scatter of the next); then compound 1.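

In this assay the low number of compound 3 is lost when ethyl takes the place of (oxetan-3-yl)oxy on the amide-type nitrogen (an 11-fold higher number from compound 3 to compound 4 (1.04 log units; beyond the scatter)). Ethyl and isopropoxy on this nitrogen cannot be told apart (a 1.3-fold higher number from compound 2 to compound 4 (0.13 log units; within the scatter)), so of the three groups shown there, only the (oxetan-3-yl)oxy of compound 3 stands apart, and an oxygen on this nitrogen is not enough to set a group apart from ethyl. Ethyl(methyl)carbamoyl in place of phenyl on the aromatic carbon still gives a lower number (a 2.2-fold lower number from compound 1 to compound 4 (0.34 log units; beyond the scatter)), so that difference needs no oxygen on the nitrogen.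

No measurement available here explains these differences. Open, from the compounds shown here alone, is whether the four-membered ring alone carries the effect, as oxetan-3-yl bonded directly to the nitrogen, or a morpholine amide or a 2-methoxyethyl chain would show.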